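Adding a third arylsulfanyl group to a quinoline lactone

The source may hold more compounds than are shown below. What is called first, only, known or untested is meant among the compounds shown, and "the series" means these compounds.

Measured compounds:
- Compound 1 `CC(C)c1ccc(Sc2cc3c(Sc4ccc(C(C)C)cc4)c(/C=C/[C@@H]4C[C@@H](O)CC(=O)O4)cnc3c(Sc3ccc(C(C)C)cc3)c2Sc2ccc(C(C)C)cc2)cc1`: 4350 nM
- Compound 2 `CC(C)c1ccc(Sc2ccc3c(Sc4ccc(C(C)C)cc4)c(/C=C/[C@@H]4C[C@@H](O)CC(=O)O4)cnc3c2)cc1`: 15800 nM

Both compounds were tested in an assay (strain Holtzman-Sprague-Dawley) for inhibition of 3-hydroxy-3-methylglutaryl-coenzyme A reductase (Rattus norvegicus), with a stated time of 30 min; on this read-out lower numbers stand for stronger inhibition and higher numbers for weaker inhibition. Compound 2 stands at the higher of the two numbers, with compound 1 giving the lower value; the gap between them is wider than the usual scatter of repeated measurements, so compound 1 is the stronger inhibitor of the pair. Among the compounds with values here, no single-point step between the two measured compounds can be counted, since they differ in more than one place.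

Compound 3 `CC(C)c1ccc(Sc2cc3ncc(/C=C/[C@@H]4C[C@@H](O)CC(=O)O4)c(Sc4ccc(C(C)C)cc4)c3cc2Sc2ccc(C(C)C)cc2)cc1` is not yet measured. It differs from compound 2 by (4-isopropylphenyl)sulfanyl in place of hydrogen on an aromatic carbon. This moves the structure part of the way toward compound 1, which carries more such groups. Compound 3 is therefore expected to give a number between those of compound 2 and compound 1, with the step of a 2.0-fold lower number from compound 2 to compound 3 (0.30 log units; within the scatter) estimated toward stronger inhibition. The expected value for compound 3 is 8000 nM, within a range of 3000 nM to 25000 nM.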

Compound 3, half-maximal inhibitory concentration: 14200 nM
For compound 3 the middle estimate is 1.8-fold (0.25 log units) below the measured one; measured number inside the range.
By their numbers in this assay, from the lowest: compound 1; then compounds 3 and 2 (each within the scatter of the next).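

In this assay, putting a (4-isopropylphenyl)sulfanyl group on this aromatic carbon, ortho to a (4-isopropylphenyl)sulfanyl group, gives a 1.1-fold lower number from compound 2 to compound 3 (0.05 log units; within the scatter), so the two compounds cannot be told apart even though the new group brings 10 heavy atoms. The one-place comparison with the more heavily substituted compound shows a 3.3-fold higher number from compound 1 to compound 3 (0.51 log units; beyond the scatter), so the difference that stands beyond the scatter belongs to the further (4-isopropylphenyl)sulfanyl group on compound 1, at a different aromatic carbon, rather than to the one added here. No measured information is available to explain either result.

Going by these compounds, whether a methoxy or an amino group on this same carbon would also leave the number within the scatter remains open. On these data alone, it is also open whether any of these patterns would hold with a different group in place of the 4-isopropylphenyl part, such as an unsubstituted phenyl ring.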